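A few compounds are considered here, and "the series" means these few. Any claim that something is new, unique, unknown or untested is made for them only; others in the source may bear on it.

Three close relatives share one core. Compound 1 `CC(Sc1nnc(-c2ccncc2)s1)C(=O)NCc1ccccc1Cl` and compound 2 `O=C(CSc1nnc(-c2ccncc2)s1)NCc1ccccc1Cl` both carry a 2-chlorobenzyl group, while compound 3 `O=C(CCSc1nnc(-c2ccncc2)s1)Nc1ccccc1Cl` carries 2-chlorophenyl. In an ADME assay on HepG2 cells (Homo sapiens) for cytotoxicity, with a stated time of 3 days (a higher number here means that more compound is tolerated, a lower number that less compound is tolerated), compound 1 reaches only a limit, > 50000 nM. Compound 3 likewise reaches only a limit in this assay, > 50000 nM. For compound 2 this assay gives "not determined" (no result reported), so no number stands for it; its position is known only through its two neighbours, which both sit at the limit of > 50000 nM in this assay, at which 2 of the 3 values shown sit. Compound 4 `O=C(CSc1nnc(-c2ccncc2)s1)NCc1ccccc1` differs from compound 2 by hydrogen in place of chloro on an aromatic carbon. For the measured compounds named here, with no measured step to lean on, any shift in this assay is expected to stay within the scatter, in either direction. Compound 4 is therefore expected to give 50000 nM, with a likely range from 20000 nM to 100000 nM, most probably reported again only as a limit.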

Compound 4, half-maximal cytotoxic concentration: 17700 nM
Estimate against measurement, compound 4: 2.8-fold (0.45 log units) above, outside the stated range (below it).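

In this assay, for the compounds shown here, compound 2 has no number, so no step to compound 4 can be read. The compounds shown leave open how going from 2-chlorobenzyl to benzyl changes the concentration tolerated.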